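The source may hold more compounds than are shown below. What is called first, only, known or untested is meant among the compounds shown, and "the series" means these compounds.

Of the compounds shown here, two sharing one core have so far been tested in an assay on CHO cells for agonist activity at transient receptor potential cation channel subfamily V member 1 (Homo sapiens); a higher number here means that more compound is needed for the effect, a lower number that less compound is needed. Compound 1 `O=C(NCc1ccc(C(F)(F)F)nc1N1CCCC1)Nc1cccc2c(=O)[nH]ccc12` gives 258 nM. Among the compounds with values here, compound 2 `CC(C)COc1nc(C(F)(F)F)ccc1CNC(=O)Nc1cccc2c(=O)[nH]ccc12` gives 78.7 nM, the lowest of the two numbers, and the single step recorded is a 3.3-fold lower number from compound 1 to compound 2 (0.52 log units; beyond the scatter). Compound 3 `O=C(NCc1ccc(C(F)(F)F)nc1OCC1CCCC1)Nc1cccc2c(=O)[nH]ccc12` has not yet been tested. It differs from compound 2 by cyclopentyl in place of isopropyl on a saturated chain carbon bound to an oxygen on an aromatic ring. Within the data shown here, no measured step addresses this kind of exchange: the one step available, from compound 1 to compound 2, swapped pyrrolidin-1-yl for isobutoxy on an aromatic carbon, a different alteration of the same region, so it offers no direct guide to size or direction here. The step from compound 2 to compound 3 is therefore expected to be a 1.3-fold lower number from compound 2 to compound 3 (0.12 log units; within the scatter), small enough to sit within or close to the usual scatter. Compound 3 is accordingly estimated to give about 60 nM, with a likely range from 20 nM to 180 nM.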

Compound 3, half-maximal effective concentration: 15.5 nM
Beside the measured number, compound 3's estimate is 3.9-fold (0.59 log units) above it; measured number below the stated range.
By their numbers in this assay, from the lowest: compound 3; then compound 2; then compound 1.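

In this assay the far end of the oxygen-linked chain turns out to matter: cyclopentyl in place of isopropyl gives a 5.1-fold lower number from compound 2 to compound 3 (0.71 log units; beyond the scatter) while the oxygen and the chain carbon bound to it stay the same. The earlier step changed the whole group on the aromatic carbon, and the full change from pyrrolidin-1-yl to cyclopentylmethoxy now gives a 17-fold lower number from compound 1 to compound 3 (1.22 log units; beyond the scatter) and leaves compound 3 with the lowest number of the three. Nothing available explains why this exchange lowers the number.

The compounds shown do not separate the effect of the ring from that of the extra carbons, which an open-chain group such as n-pentyl could help to do. Going by these compounds, it also remains open how far this trend extends, for example to a larger ring such as cyclohexyl or to an aromatic ring such as phenyl on the same chain carbon.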